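A few compounds are considered here, and "the series" means these few. Any claim that something is new, unique, unknown or untested is made for them only; others in the source may bear on it.

Compound 1 `COc1ccc(C(=O)/C=C/c2ccc(C(F)(F)F)cc2)c2c1C=CC(C)(C)O2` and compound 2 `COc1ccc(C(=O)/C=C/c2ccsc2)c2c1C=CC(C)(C)O2` share one core, a chalcone-like chain that joins the core to a ring that is swapped from one compound to the next. In a functional assay on HT-29 cells (Homo sapiens) for antiproliferative activity, read by MTT assay, with a stated time of 24 h (a higher number here means a weaker inhibitor, a lower number a stronger inhibitor), compound 1 gives > 10000 nM, which is a limit of the assay and not a number. In this assay compound 2 gives > 10000 nM, again a limit and not a number. Both measured values therefore sit at the same point, as the summary shows: the limit of > 10000 nM in this assay, at which 2 of the 2 values shown sit. The next compound, compound 3 `COc1ccc(C(=O)/C=C/c2ccc(O)c(Br)c2)c2c1C=CC(C)(C)O2`, differs from compound 2 in one place: 3-bromo-4-hydroxyphenyl in place of thiophen-3-yl on a double-bonded chain carbon bound to a double-bonded chain carbon. Among the compounds with values here, no measured step tells how such a change behaves here, so the expectation rests only on the two limits. The step from compound 2 to compound 3 is expected to be an at least 1.1-fold lower number from compound 2 to compound 3 (0.04 log units; that floor lies within the scatter), a modest move toward stronger inhibition at most. Compound 3 is therefore estimated at 9000 nM, with a range from 2500 nM to 35000 nM.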

Compound 3, half-maximal inhibitory concentration: > 10000 nM
Compound 3: no number, only a limit; the forecaster's own chance of this, stated with the estimate: 50%; middle value at least 1.1-fold (0.04 log units) from the limit.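

In this assay compound 3 gives > 10000 nM, which is a limit and not a number. The step from compound 2 to compound 3 therefore cannot be read, and all three compounds sit at one point: the limit of > 10000 nM in this assay, at which 3 of the 3 values shown sit. Going by these compounds, how far past that limit each compound lies remains open, as does whether 3-bromo-4-hydroxyphenyl or thiophen-3-yl gives the stronger inhibitor.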